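The compounds below may be only part of what the source reports. "The series", "measured", "known", "first", "only" and "open" are said of these compounds alone.

Measured compounds:
compound 1 `CCn1c(=O)/c(=C2\Sc3ccccc3N2C)s/c1=C\c1ccncc1Nc1ccccc1F`: 330 nM
compound 2 `CCn1c(=O)/c(=C2\Sc3ccc(OC)cc3N2C)s/c1=C\c1ccncc1Nc1ccccc1Cl`: 710 nM

Both values come from a functional assay on MCF7 cells (Homo sapiens) for inhibition; on this read-out higher numbers stand for weaker inhibition and lower numbers for stronger inhibition. Compound 2 gives the higher of the two numbers; its nearest neighbour is compound 1, whose value lies beyond the usual scatter of this assay. The two compounds differ in more than one place, so the two numbers alone do not separate the contributions of the individual changes.

Compound 3 `CCn1c(=O)/c(=C2\Sc3ccc(OC)cc3N2C)s/c1=C\c1ccncc1Nc1ccccc1F` is not yet measured. It differs from compound 2 in one place: fluoro in place of chloro on an aromatic carbon. For the measured compounds named here, no pair of measured compounds shows this change on its own, so no measured step is available for it. The expectation is a small step, if any, with a slight lean toward a lower number, since compound 1 carries the fluoro and gives 330 nM. For compound 3 the estimated value is 480 nM, with a range from 200 nM to 1100 nM, which corresponds to an expected step of a 1.5-fold lower number from compound 2 to compound 3 (0.17 log units; within the scatter).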

Compound 3, half-maximal inhibitory concentration: 130 nM
Compound 3: the middle estimate sits 3.7-fold (0.57 log units) above what was measured; the whole stated range lies above it.
By their numbers in this assay, from the lowest: compound 3; then compound 1; then compound 2.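

In this assay the change from 2-chlorophenyl to 2-fluorophenyl now has a size of its own: a 5.5-fold lower number from compound 2 to compound 3 (0.74 log units; beyond the scatter) shows that this aromatic carbon, ortho to a large group, responds to the swap of a single halogen. With the fluoro held fixed, methoxy in place of hydrogen can also be read alone, and a 2.5-fold lower number from compound 1 to compound 3 (0.40 log units; beyond the scatter) places the compound carrying both groups lowest of the three. Nothing at hand explains either step.

On these data alone, the halogen step is known only with the methoxy present and the methoxy step only with the fluoro present, so whether the two steps add remains open. Also open, as far as these compounds go, is how a bromo or methyl on the same aromatic carbon, or a hydroxy or dimethylamino group in place of the methoxy, would read.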